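This account rests on a few compounds, and the source may have more. Where it says the series, first, only, none or still open, it means among the compounds named here.

Compound 1, `CCOC(=O)c1sc(-c2cccc(NC(=O)c3ccc(C(C)(C)C)cc3)c2)nc1Nc1ccc(N2CCN(C)CC2)cc1`: 21.2%
Compound 2, `CN1CCN(c2ccc(Nc3nc(-c4cccc(NC(=O)c5ccc(F)c(Cl)c5)c4)sc3C(=O)O)cc2)CC1`: 98.6%
Compound 3, `CN1CCN(c2ccc(Nc3nc(-c4cccc(NC(=O)c5ccc(C(C)(C)C)cc5)c4)sc3C(N)=O)cc2)CC1`: 80.1%

In a functional assay on Ramos cells (Homo sapiens) for antiproliferative activity, read by CCK-8 assay, with a stated time of 72 h, tested at 40 uM (a higher number here means more inhibition at the concentration tested (going by the name of the read-out), a lower number less inhibition), compound 3 stands second highest of the three measured compounds. Compound 2 gives 98.6%, a value above that of compound 3 and beyond the scatter. For the measured compounds named here, compound 1 gives 21.2%, far below compound 3; the only single-point step measured, a number 58.9 percentage points higher from compound 1 to compound 3 (beyond the scatter), comes from amino in place of ethoxy on a carbonyl carbon, and it is large.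

Compound 4, `CN1CCN(c2ccc(Nc3nc(-c4cccc(NC(=O)[C@H]5CC[C@H](C)CC5)c4)sc3C(N)=O)cc2)CC1`, has not yet been measured. It differs from compound 3 in one place: 4-methylcyclohexyl in place of 4-(tert-butyl)phenyl on a carbonyl carbon. The primary carboxamide of compound 3 is kept. Going by the values given here, no measured step concerns the group on the amide carbonyl: the step from compound 1 to compound 3 changes the carbonyl substituent on the shared core, not the amide, and compound 2 differs from compound 3 in two places, so its value alone gives no guidance here. The expectation for compound 4 therefore rests mainly on the retained carboxamide of compound 3 and carries a wide range. In this assay compound 4 is expected to give about 70%, between 40% and 95%. The estimated step, a number 10.1 percentage points lower from compound 3 to compound 4 (beyond the scatter), is thus expected to stay within or close to the scatter, with the direction uncertain.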

Compound 4, a percentage reported as inhibition, at one concentration (the size of the read-out at that concentration, not a potency): 55.1%
For compound 4 the middle estimate is 14.9 percentage points above the measured one, and the stated range covers the measured number.
By their numbers in this assay, from the lowest: compound 1; then compound 4; then compound 3; then compound 2.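

For the compounds shown here, the group on the amide carbonyl, which no earlier step touched, affects the read-out in this assay: 4-methylcyclohexyl in place of 4-(tert-butyl)phenyl on a carbonyl carbon gives a number 25 percentage points lower from compound 3 to compound 4 (beyond the scatter). Going by these compounds alone, the carboxamide of compound 3 is kept in compound 4, so this position changes the result on its own, although the change replaces a six-membered aromatic ring of carbon only with a six-membered non-aromatic ring of carbon only and also removes heavy atoms, and the single step cannot separate these two differences. No measurement available here accounts for the lower number.

The compounds shown leave open whether the loss follows the non-aromatic ring, the smaller group or the two defined stereocentres of compound 4. On the same carbonyl carbon, 4-methylphenyl would compare directly with compound 4 and 4-(tert-butyl)cyclohexyl directly with compound 3, and the other stereoisomer of 4-methylcyclohexyl would address the stereocentres.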